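Methoxy in place of fluoro: compound 3 to compound 4

A few compounds are considered here, and "the series" means these few. Any claim that something is new, unique, unknown or untested is made for them only; others in the source may bear on it.

In a physicochemical assay for solubility, read by LC-MS, using the shake flask method, measured as thermodynamic solubility, with a stated time of 24 h, at pH 6.5 (a higher number here means a more soluble compound, a lower number a less soluble compound), compound 3 `OC[C@H]1O[C@H](OCc2cn(-c3ccc(F)cc3)nn2)[C@@H](O)[C@@H](O)[C@@H]1O` reads > 3000 ug/mL, which is a limit and not a number. Compound 1 `COc1ccc(Cn2cc(CO[C@H]3O[C@H](CO)[C@@H](O)[C@H](O)[C@@H]3O)nn2)cc1` reads > 3000 ug/mL, which is also a limit. Compound 2 `O=[N+]([O-])c1ccc(-n2cc(CO[C@H]3O[C@H](CO)[C@@H](O)[C@H](O)[C@@H]3O)nn2)cc1` gives an actual number, 2600 ug/mL. The series therefore sits largely at the limit of > 3000 ug/mL in this assay, at which 2 of the 3 values shown sit, and the position of compound 3 is only bounded.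

Compound 4 `COc1ccc(-n2cc(CO[C@H]3O[C@H](CO)[C@@H](O)[C@H](O)[C@@H]3O)nn2)cc1` keeps the shared core and carries methoxy in place of fluoro on an aromatic carbon, para to a large group (methoxy in place of fluoro on an aromatic carbon). Among the compounds with values here, no measured step makes this exact change, but three steps alter the same aryl end of the molecule. Fluoro in place of nitro gave an at least 1.1-fold higher number from compound 2 to compound 3 (0.06 log units; that floor lies within the scatter). 4-Nitrophenyl in place of 4-methoxybenzyl gave an at least 1.1-fold lower number from compound 1 to compound 2 (0.06 log units; that floor lies within the scatter). 4-Fluorophenyl in place of 4-methoxybenzyl gave a step that the two limits leave unreadable from compound 1 to compound 3. None of these steps shows a change beyond the scatter, so none beyond the scatter is expected here either, although the limits leave real differences hidden. The estimated change is an at least 1.0-fold lower number from compound 3 to compound 4 (0.02 log units; that floor lies within the scatter). The reading may well arrive as a limit again. For compound 4 the expected value is 2800 ug/mL, with an estimated range from 1400 ug/mL to 3500 ug/mL.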

Compound 4, solubility: 2600 ug/mL
For compound 4 the middle estimate is 1.1-fold (0.03 log units) above the measured one; low and high end bracket the measured number.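

In this assay, methoxy on the aromatic carbon para to a large group gives an at least 1.1-fold lower number from compound 3 to compound 4 (0.06 log units; that floor lies within the scatter), a floor and not a measured size. Set against nitro at the same place, methoxy gives no change at the digits printed from compound 2 to compound 4 (within the scatter), so this position now carries two real numbers rather than one, and those two groups cannot be told apart here. Within the data shown here, with the methoxy group kept in both compounds, replacing the 4-methoxybenzyl group with the 4-methoxyphenyl group gives an at least 1.1-fold lower number from compound 1 to compound 4 (0.06 log units; that floor lies within the scatter), which isolates that change for the first time, though again only as a floor within the scatter.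

The true distance of compound 1 and compound 3 from the two real numbers stays hidden, since the readings of both compounds are limits and the series still rests heavily on that limit: the limit of > 3000 ug/mL in this assay, at which 2 of the 4 values shown sit. On these data alone, whether an amine or a carboxylic acid on this aromatic carbon, or a chain longer than methoxy, would move the reading beyond the scatter remains open.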